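A Halogen Swap With Little Expected Change in Cytotoxicity

The compounds below may be only part of what the source reports. "The series", "measured", "known", "first", "only" and "open" are said of these compounds alone.

Compound 2 `O=C(Nc1ccc(Cl)cc1F)c1cc(F)ccc1O` was tested in an ADME assay on RAW264.7 cells (Mus musculus) for cytotoxicity, read by MTT assay, with a stated time of 24 h (on this read-out higher numbers stand for lower toxicity in this test and lower numbers for higher toxicity in this test), and gives 7700 nM. Its number is the lowest of the three measured here, but compound 1 `O=C(Nc1ccc(Cl)cc1F)c1cc(I)ccc1O` gives 8500 nM and compound 3 `O=C(Nc1ccc(Br)cc1F)c1cc(F)ccc1O` gives 7900 nM, so all three sit within the usual scatter of one another and no real order can be read from them.

Compound 4 `O=C(Nc1ccc(Cl)cc1F)c1cc(Br)ccc1O` has not yet been measured. It differs from compound 2 by bromo in place of fluoro on an aromatic carbon.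

Two measured steps speak to this change. The step of a 1.1-fold lower number from compound 1 to compound 2 (0.04 log units; within the scatter) exchanges one halogen for another at the very same position, and the step of a 1.0-fold higher number from compound 2 to compound 3 (0.01 log units; within the scatter) exchanges halogens at another position; both stayed within the scatter. Another halogen swap at the same place is therefore expected to leave this assay essentially unchanged, with a 1.0-fold higher number from compound 2 to compound 4 (0.02 log units; within the scatter) as the expected step.

Compound 4 is estimated to give 8000 nM, with a range from 5000 nM to 13000 nM.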

Compound 4, half-maximal cytotoxic concentration: 9200 nM
Compound 4: the middle estimate sits 1.2-fold (0.06 log units) below what was measured; low and high end bracket the measured number.
By their numbers in this assay, from the lowest: compounds 2, 3, 1 and 4 (each within the scatter of the next).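

With compound 4, this position para to a hydroxy group has carried fluoro, bromo and iodo, and in this assay the two new comparisons show a 1.2-fold higher number from compound 2 to compound 4 (0.08 log units; within the scatter) for bromo in place of fluoro and a 1.1-fold higher number from compound 1 to compound 4 (0.03 log units; within the scatter) for bromo in place of iodo. For the compounds shown here, the earlier compounds offered only one swap at this place, fluoro for iodo, whereas all three halogens can now be compared there directly, and each pair lies within the scatter. No measured information is available to explain this outcome.

On these data alone, every group tested at this position is a halogen, so it remains open whether an amine, a carboxylic acid or a longer chain there would also stay within the scatter. As far as these compounds go, it is also open whether replacing the hydroxy group itself would shift the number in this test.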